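The compounds below may be only part of what the source reports. "The series", "measured", "known", "first", "only" and "open" are said of these compounds alone.

Working notes on the series, read in a functional assay on MCF7 cells (Homo sapiens) for inhibition, read by sulforhodamine B assay, with a stated time of 48 h; a higher number here means a weaker inhibitor of growth, a lower number a stronger inhibitor of growth. Compound 1 (`O=C(CCCCN1C/C=C/CCOc2cccc(c2)-c2ccnc(n2)Nc2cccc(c2)C1)NO`) gives 1130 nM. For the measured compounds named here, compound 2 (`O=C(CCCCCCN1C/C=C/COCc2cccc(c2)-c2ccnc(n2)Nc2cccc(c2)C1)NO`) gives 1130 nM, so the two stand level, within the scatter, and compound 1 shows no separation from the only other measured member of the series.

The next member is compound 3 (`O=C(CCCCC(=O)N1C/C=C/CCOc2cccc(c2)-c2ccnc(n2)Nc2cccc(c2)C1)NO`). In it, (4-(hydroxycarbamoyl)butyl)carbonyl takes the place of 4-(hydroxycarbamoyl)butyl on an amine nitrogen in a ring: (4-(hydroxycarbamoyl)butyl)carbonyl in place of 4-(hydroxycarbamoyl)butyl on an amine nitrogen in a ring. The rest of the structure of compound 1 stays as it is.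

Going by the values given here, no measured pair shows the effect of this kind of change, so any expected direction rests on little evidence. The natural anchor is compound 1 at 1130 nM. No step beyond the scatter is expected, with only a slight lean towards a weaker inhibitor of growth, and the expected change is a 1.3-fold higher number from compound 1 to compound 3 (0.12 log units; within the scatter). The range is kept wide to reflect the lack of a measured precedent. In this assay, the estimate for compound 3 is 1500 nM, with an expected range from 500 nM to 5000 nM.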

Compound 3, concentration for 50% growth inhibition: 2090 nM
Estimate against measurement, compound 3: 1.4-fold (0.14 log units) below; the range from low to high includes it.
By their numbers in this assay, from the lowest: compounds 1, 2 and 3 (each within the scatter of the next).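

In this assay, the step at the amine nitrogen in a ring is a 1.8-fold higher number from compound 1 to compound 3 (0.27 log units; within the scatter), so the (4-(hydroxycarbamoyl)butyl)carbonyl and 4-(hydroxycarbamoyl)butyl groups cannot be told apart at this position in this read-out. For the compounds shown here, this is the first reading of a single change at this position: the earlier compounds gave no pair that differed in one place, and compound 3 now shows that a carbonyl can stand on this ring nitrogen without a step beyond the scatter. Nothing available bears on why the two groups read alike, and one pair gives no trend for the position.

What the compounds shown leave open is whether this result holds for other groups on the same ring nitrogen, such as a longer chain joined through a carbonyl or a sulfonyl link to the same chain. As far as these compounds go, it is also open whether a carboxylic acid in place of the hydroxycarbamoyl end of the chain would give a step beyond the scatter when either the carbonyl-linked or the directly attached chain is present.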